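Isopropyl Added to the Phenoxy Arm of Compound 2

A few compounds are considered here, and "the series" means these few. Any claim that something is new, unique, unknown or untested is made for them only; others in the source may bear on it.

Measured compounds:
compound 1, `CO[C@@H]1O[C@H](COc2cccc(C(C)C)c2)[C@@H](O)[C@H](O)[C@H]1Oc1ccc(OC2CCCCC2)cc1`: 40000 nM
compound 2, `CO[C@H]1O[C@H](COc2ccccc2)[C@@H](O)[C@H](O)[C@H]1Oc1ccc(OC2CCCCC2)cc1`: "not determined" (no result reported)

In a functional assay on MDA-MB-231 cells (Homo sapiens) for cytotoxicity, read by MTT assay, with a stated time of 48 h (a higher number here means that more compound is needed for the effect, a lower number that less compound is needed), compound 1 gives 40000 nM. Within the data shown here, for compound 2 the result in this assay is "not determined" (no result reported), so compound 2 has no number to stand on; the only measured value in the set belongs to compound 1.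

Compound 3, `CO[C@H]1O[C@H](COc2cccc(C(C)C)c2)[C@@H](O)[C@H](O)[C@H]1Oc1ccc(OC2CCCCC2)cc1`, arises from compound 2 by one change: isopropyl in place of hydrogen on an aromatic carbon. Among the measured compounds shown here, since compound 2 carries no value, no step can be computed. Compound 1 carries the same isopropyl group on its phenoxy arm and shares the rest of the substitution with compound 3. The nearest guide is therefore the value of compound 1, 40000 nM. The isopropyl change is expected to move the number in this assay by no more than the usual scatter, if at all.

Compound 3 is therefore estimated to give about 40000 nM in this assay, with a range from 15000 nM to 100000 nM.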

Compound 3, half-maximal effective concentration: 38000 nM
Estimate against measurement, compound 3: 1.1-fold (0.02 log units) above; the measured number falls inside the stated range.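

In this assay the two isopropyl compounds show a 1.1-fold lower number from compound 1 to compound 3 (0.02 log units; within the scatter), so the stereocentre at the saturated ring carbon, drawn R in compound 1 and S in compound 3, has no effect here that can be told from the scatter. This comparison isolates that single stereocentre: the fact that compounds 1 and 3 differ only in the configuration as drawn. The effect of the isopropyl group itself cannot be read, since compound 2 has no number and the step from compound 2 to compound 3 therefore has no value.

On these data alone, it remains open whether an amine, a carboxylic acid or a longer chain in place of the isopropyl group would give a number apart from those of compound 1 and compound 3. As far as these compounds go, it is also open whether configuration at this carbon would matter equally little with the plain phenoxy arm of compound 2.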